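Methyl in Place of Chloro: An Expected Gain

The compounds below may be only part of what the source reports. "The series", "measured", "known", "first", "only" and "open" are said of these compounds alone.

Of the compounds shown here, three sharing one core have been measured in an assay on mitochondria for inhibition of Amine oxidase [flavin-containing] A (Bos taurus); a higher number here means a weaker inhibitor, a lower number a stronger inhibitor. Compound 1 `Cc1ccc(C2=NN(C(N)=S)C(c3ccc(Cl)cc3)C2)cc1` gives 31 nM. Compound 2 `Cc1ccc(C2=NN(C(N)=S)C(c3ccc(C)cc3)C2)cc1` gives 6 nM, and compound 3 `NC(=S)N1N=C(c2ccc(F)cc2)CC1c1ccc(Cl)cc1` gives 6 nM. Compound 2 differs from compound 1 by methyl in place of chloro on an aromatic carbon, which brought a 5.2-fold lower number from compound 1 to compound 2 (0.71 log units; beyond the scatter). Compound 3 differs from compound 1 by fluoro in place of methyl on an aromatic carbon, with a 5.2-fold lower number from compound 1 to compound 3 (0.71 log units; beyond the scatter). Compound 4 `Cc1ccc(C2CC(c3ccc(F)cc3)=NN2C(N)=S)cc1` is not yet measured; it differs from compound 3 by methyl in place of chloro on an aromatic carbon, the same change at the same place as between compound 1 and compound 2. For compound 4 the step is estimated at a 3.0-fold lower number from compound 3 to compound 4 (0.48 log units; beyond the scatter), somewhat smaller than the earlier one because a 5.2-fold lower number from compound 1 to compound 2 (0.71 log units; beyond the scatter) started from a higher number while compound 3 already stands level with compound 2. Compound 4 is therefore expected to give about 2 nM, likely between 0.6 nM and 7 nM.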

Compound 4, inhibition constant: 7 nM
Compound 4: the middle estimate sits 3.5-fold (0.54 log units) below what was measured; the measured number falls inside the stated range.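

In this assay, methyl in place of chloro gave a 1.2-fold higher number from compound 3 to compound 4 (0.07 log units; within the scatter), so the change did not repeat on this core what it had done on the core of compound 1: the same change on two cores in this assay, a 5.2-fold lower number (0.71 log units; beyond the scatter) from compound 1 to compound 2 and a 1.2-fold higher number (0.07 log units; within the scatter) from compound 3 to compound 4, 6.0-fold (0.78 log units) apart, beyond the scatter of two such steps. Fluoro in place of methyl gave a 1.2-fold higher number from compound 2 to compound 4 (0.07 log units; within the scatter), and it too failed to repeat its earlier step: the same change on two cores in this assay, a 5.2-fold lower number (0.71 log units; beyond the scatter) from compound 1 to compound 3 and a 1.2-fold higher number (0.07 log units; within the scatter) from compound 2 to compound 4, 6.0-fold (0.78 log units) apart, beyond the scatter of two such steps. In these four compounds, then, the effect of a change depends on the group elsewhere in the molecule, but the numbers do not show why, nor how the change would behave on any other core.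

As far as these compounds go, it remains open whether another group at the same place, such as an amine or a methoxy group, would give a step like the earlier ones or like the new ones. A wider set of such pairs would show which of these steps is the more typical.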